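Replacing methoxy with methyl in compound 2

The source may hold more compounds than are shown below. What is called first, only, known or untested is meant among the compounds shown, and "the series" means these compounds.

Measured in a functional assay on A549 cells (Homo sapiens) for antiproliferative activity, read by MTT assay, with a stated time of 72 h; a higher number here means a weaker inhibitor, a lower number a stronger inhibitor:
compound 1 `Nc1nc(N)c2cc(CSC(=S)N3CCN(C4CCCCC4)CC3)ccc2n1`: 4710 nM
compound 2 `COc1ccc(N2CCN(C(=S)SCc3ccc4nc(N)nc(N)c4c3)CC2)cc1`: 1590 nM

Compound 2 holds the lower of the two numbers at 1590 nM, and compound 1 gives 4710 nM. The next compound, compound 3 `Cc1ccc(N2CCN(C(=S)SCc3ccc4nc(N)nc(N)c4c3)CC2)cc1`, keeps everything in compound 2 except one group: 4-methoxyphenyl becomes 4-methylphenyl, that is, methyl in place of methoxy on an aromatic carbon, para to a large group (methyl in place of methoxy on an aromatic carbon).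

Among the compounds with values here, only one measured step touches this substituent: 4-methoxyphenyl in place of cyclohexyl, a 3.0-fold lower number from compound 1 to compound 2 (0.47 log units; beyond the scatter), a modest step beyond the scatter. That step exchanges a whole ring, whereas the present change leaves the ring in place. Within the data shown here, no measured pair tests the methoxy group alone, so the direction stays open. In this assay no step beyond the scatter is therefore expected. The estimated step is a 1.1-fold higher number from compound 2 to compound 3 (0.03 log units; within the scatter). For compound 3 the expected value is 1700 nM, with an estimated range of 700 nM to 4200 nM.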

Compound 3, half-maximal inhibitory concentration: 2190 nM
Compound 3: middle estimate off by 1.3-fold (0.11 log units), on the low side; measured number inside the range.
By their numbers in this assay, from the lowest: compounds 2 and 3 (each within the scatter of the next); then compound 1.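

In this assay, within the data shown here, methyl in place of methoxy on an aromatic carbon, para to a large group, gives a 1.4-fold higher number from compound 2 to compound 3 (0.14 log units; within the scatter), the first comparison that isolates this substituent; removing the oxygen, and with it the one hydrogen-bond acceptor counted on methoxy, leaves the number within the scatter. The advantage over cyclohexyl also persists without methoxy, with a 2.2-fold lower number from compound 1 to compound 3 (0.33 log units; beyond the scatter) alongside a 3.0-fold lower number from compound 1 to compound 2 (0.47 log units; beyond the scatter), so in these two pairs it does not depend on having methoxy rather than methyl on the aromatic ring. No measured evidence bears on why the methoxy-to-methyl change leaves the number within the scatter.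

Two small neutral groups at this position do not show how far that tolerance extends, and a carboxylic acid, an amine or a trifluoromethyl group there could still separate from compound 2 beyond the scatter. Going by these compounds, it is also open whether the aromatic ring alone carries the advantage over cyclohexyl, a question that plain phenyl, with hydrogen at this position, would address.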